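The compounds below may be only part of what the source reports. "The series", "measured", "known", "first", "only" and "open" are said of these compounds alone.

Measured compounds in an assay on isolated protein for inhibition of tyrosine-protein kinase receptor UFO (Homo sapiens), read by FRET and Z'-LYTE, with a stated time of 1.5 h; on this read-out higher numbers stand for weaker inhibition and lower numbers for stronger inhibition:

- compound 1 `Cc1c(C(=O)Nc2ccc(Oc3ncnc4[nH]cc(-c5ccccc5)c34)c(F)c2)c(=O)c2cc(Cl)ccc2n1C`: compound 1 gives 1890 nM
- compound 2 `Cc1c(C(=O)Nc2ccc(Oc3ncnc4[nH]cc(-c5ccccc5)c34)c(F)c2)c(=O)c2cc(C(F)(F)F)ccc2n1C`: compound 2 gives 150 nM
- compound 3 `CCn1c(C)c(C(=O)Nc2ccc(Oc3ncnc4[nH]cc(-c5ccccc5)c34)c(F)c2)c(=O)c2cc(C)ccc21`: compound 3 gives 150 nM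

Compound 2 sits at the low end of this small set. Its number and that of compound 3 agree at the digits shown, so nothing separates the two, while compound 1 lies well apart: a 13-fold lower number from compound 1 to compound 2 (1.10 log units; beyond the scatter).

Compound 4 `Cc1c(C(=O)Nc2ccc(Oc3ncnc4[nH]cc(-c5ccccc5)c34)c(F)c2)c(=O)c2cc(C3CC3)ccc2n1C` has not yet been measured. It is compound 2 with one change: cyclopropyl in place of trifluoromethyl on an aromatic carbon.

Among the measured compounds shown here, only one measured step touches this position, a 13-fold lower number from compound 1 to compound 2 (1.10 log units; beyond the scatter), and it shows that the group at this place can shift this assay strongly. For the measured compounds named here, no measured compound carries a cyclopropyl anywhere, so there is no direct guide to the new group. Compound 3 carries a methyl at the same place and gives 150 nM, but it also differs from compound 2 elsewhere, so it only hints that a carbon-based group here is tolerated.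

The expectation for compound 4 is therefore a number close to compound 2, with a step of a 1.5-fold higher number from compound 2 to compound 4 (0.17 log units; within the scatter) that may fall inside the scatter, and the estimate for compound 4 is 220 nM, with a range from 60 nM to 800 nM.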

Compound 4, half-maximal inhibitory concentration: 230 nM
Beside the measured number, compound 4's estimate is 1.0-fold (0.02 log units) below it; measured number inside the range.
By their numbers in this assay, from the lowest: compounds 2, 3 and 4 (each within the scatter of the next); then compound 1.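

In this assay, the step of a 1.5-fold higher number from compound 2 to compound 4 (0.19 log units; within the scatter) comes with cyclopropyl, a three-membered ring of carbon only, in place of trifluoromethyl, which has three fluorines on one carbon, and it leaves the two groups indistinguishable at this position. The second step, an 8.2-fold lower number from compound 1 to compound 4 (0.91 log units; beyond the scatter) for cyclopropyl in place of chloro, shows that the wide gap at this position is no longer tied to trifluoromethyl alone: among the three groups compared directly here, chloro stands apart from two quite different groups. No supporting measurement explains why chloro differs or why these two groups match.

Compound 3 differs from the others in a second place as well, so the effect of a methyl alone at this position remains unresolved. The compounds shown also leave open how this position responds to groups containing oxygen or nitrogen, such as a methoxy, an amine or a carboxylic acid, and to a longer carbon chain such as butyl.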